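Aryl variation on the shared core: from compound 2 to compound 3

The source may hold more compounds than are shown below. What is called first, only, known or untested is meant among the compounds shown, and "the series" means these compounds.

For the measured compounds named here, compound 2 `CCC1=C(O)c2c(oc(-c3ccccc3C)cc2=O)C(CC)(CC)C1=O` gives 2.41 uM in a functional assay on KBVIN cells (Homo sapiens) for antiproliferative activity, read by sulforhodamine B assay, with a stated time of 3 days (on this read-out lower numbers stand for an effect already at smaller amounts and higher numbers for an effect only at larger amounts of compound), the lowest of the two numbers measured so far. Going by the values given here, its nearest neighbour is compound 1 `CCOc1ccc(-c2cc(=O)c3c(o2)C(CC)(CC)C(=O)C(CC)=C3O)cc1`, which in this assay gives 7.54 uM; the one step between them, a 3.1-fold lower number from compound 1 to compound 2 (0.50 log units; beyond the scatter), is the only measured step and comes from exchanging the aryl group on the shared core.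

Compound 3 `CCC1=C(O)c2c(oc(-c3ccc(OC)c(Cl)c3)cc2=O)C(CC)(CC)C1=O` has not yet been measured. It differs from compound 2 in one place: 3-chloro-4-methoxyphenyl in place of 2-methylphenyl on an aromatic carbon. The step from compound 1 to compound 2 bears on this change only in part, since it also exchanged the aryl group but replaced a 4-ethoxyphenyl rather than introducing a 3-chloro-4-methoxyphenyl. Among the compounds with values here, because the only measured aryl exchange, a 3.1-fold lower number from compound 1 to compound 2 (0.50 log units; beyond the scatter), moved the number by a modest amount, the expected step for compound 3 in this assay is a 2.1-fold higher number from compound 2 to compound 3 (0.32 log units; beyond the scatter), a modest rise back toward the number of compound 1. The estimate for compound 3 in this assay is 5 uM, with a range from 2 uM to 12 uM.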

Compound 3, concentration for half-maximal effect: 1.37 uM
Compound 3: the middle estimate sits 3.6-fold (0.56 log units) above what was measured; the measured number lies below the stated range.
By their numbers in this assay, from the lowest: compounds 3 and 2 (each within the scatter of the next); then compound 1.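

In this assay, the aryl position now holds two quite different groups with no separation beyond the scatter: a 1.8-fold lower number from compound 2 to compound 3 (0.25 log units; within the scatter), although 3-chloro-4-methoxyphenyl is larger than 2-methylphenyl by the chlorine and the methoxy oxygen and brings a hydrogen-bond acceptor. The 4-ethoxyphenyl of compound 1 now stands apart from both other aryl groups, with a 5.5-fold lower number from compound 1 to compound 3 (0.74 log units; beyond the scatter) adding to the earlier 3.1-fold lower number from compound 1 to compound 2 (0.50 log units; beyond the scatter), and the presence of an alkoxy group on the aryl ring does not by itself go with the higher number, as compound 3 carries a methoxy group and still reads with compound 2 rather than with compound 1. Nothing available explains why the 4-ethoxyphenyl group differs from the other two aryl groups.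

The three compounds cannot separate the share of the chlorine from that of the methoxy group, so a plain 3-chlorophenyl or 4-methoxyphenyl group on the shared core remains an open comparison. Also open, as far as these compounds go, is how this position responds to an aryl group bearing an amine or a carboxylic acid, or to a longer alkoxy chain than ethoxy.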